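Hydrazone aryl swap: pyridin-2-yl to 4-hydroxyphenyl

The source may report more compounds than this note shows. Statements on the series, on what has been measured and on what is new or still open speak of the compounds shown alone.

Measured compounds in an ADME assay on THP-1 cells (Homo sapiens) for cytotoxicity; on this read-out lower numbers stand for stronger inhibition and higher numbers for weaker inhibition:
compound 1 `COc1ccccc1-c1nnc(-c2ccc(C(=O)N/N=C/c3ccccc3[N+](=O)[O-])cc2)o1` gives 161000 nM
compound 2 `COc1ccccc1-c1nnc(-c2ccc(C(=O)N/N=C/c3cccnc3)cc2)o1` gives 167000 nM
compound 3 `COc1ccccc1-c1nnc(-c2ccc(C(=O)N/N=C/c3ccccn3)cc2)o1` gives 67000 nM

In this assay compound 3 gives the lowest number of the three, and its steps to compound 1 and compound 2 are both beyond the scatter, so it is the strongest inhibitor measured. Compound 4 `COc1ccccc1-c1nnc(-c2ccc(C(=O)N/N=C/c3ccc(O)cc3)cc2)o1` differs from it by 4-hydroxyphenyl in place of pyridin-2-yl on a carbon with a double bond to nitrogen. Two measured steps change the same position: a 2.4-fold lower number from compound 1 to compound 3 (0.38 log units; beyond the scatter) and a 2.5-fold lower number from compound 2 to compound 3 (0.40 log units; beyond the scatter). Both were modest, and compound 1 and compound 2 sit close together with different aryl groups there, with compound 3 apart. Among the measured compounds shown here, no direct analogue of the 4-hydroxyphenyl group has been measured. The expected step is a 1.8-fold higher number from compound 3 to compound 4 (0.25 log units; within the scatter), back toward the numbers of compound 1 and compound 2. Compound 4 is estimated at 120000 nM, with a range from 50000 nM to 300000 nM.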

Compound 4, half-maximal inhibitory concentration: 261000 nM
Beside the measured number, compound 4's estimate is 2.2-fold (0.34 log units) below it, and the stated range covers the measured number.
By their numbers in this assay, from the lowest: compound 3; then compounds 1, 2 and 4 (each within the scatter of the next).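

In this assay, 4-hydroxyphenyl on a carbon with a double bond to nitrogen gives a 3.9-fold higher number from compound 3 to compound 4 (0.59 log units; beyond the scatter) and so leaves compound 3 apart from a third aryl group as well. The other two steps, a 1.6-fold higher number from compound 2 to compound 4 (0.19 log units; within the scatter) and a 1.6-fold higher number from compound 1 to compound 4 (0.21 log units; within the scatter), are within the scatter, which places compound 4 in one group with compound 1 and compound 2 and leaves pyridin-2-yl alone of the four groups with a lower number. No evidence on the reason for this separation is available.

Left open is whether a pyridin-4-yl group or an aminophenyl group at this place would fall with compound 3 or with the other three. Also open, on these data alone, is whether the separation of pyridin-2-yl holds on a different core.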